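This account rests on a few compounds, and the source may have more. Where it says the series, first, only, none or still open, it means among the compounds named here.

Compound 1 `C=C1CC(c2ccccc2)OC1=O` gives 135% in a functional assay on PANC-1 cells (Homo sapiens) for cytotoxicity, read by MTT assay, with a stated time of 72 h, tested at 10 uM; a higher number here means a weaker effect of the compound at the concentration tested, a lower number a stronger effect.
Compound 2 `C=C1C(=O)O[C@@H](c2ccccc2)[C@H]1C` gives 62% in this assay.
Compound 3 `C=C1C(=O)O[C@@H](C(C)C)[C@H]1C` gives 119% in this assay.

Among these three, compound 2 stands at the lowest number, and its gaps to compound 3 and to compound 1 both lie beyond the usual scatter, so compound 2 shows the strongest effect of the measured set. Compound 4 `C=C1C(=O)O[C@@H](c2ccc(OC)cc2)[C@H]1C` has not yet been measured. It differs from compound 2 in one place: methoxy in place of hydrogen on an aromatic carbon. Among the compounds with values here, no step of this kind is available in the data, so what the methoxy group does here is unknown. In this assay, the expectation is a change in the direction of a weaker effect of about a number 6 percentage points higher from compound 2 to compound 4 (within the scatter) from compound 2, which is within the scatter. Compound 4 is therefore estimated at 68%, with a range from 40% to 100%.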

Compound 4, a percentage reported as activity, at one concentration (the size of the read-out at that concentration, not a potency): 32%
Beside the measured number, compound 4's estimate is 36 percentage points above it; measured number outside the range, below it.
By their numbers in this assay, from the lowest: compound 4; then compound 2; then compound 3; then compound 1.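

Within the data shown here, the methoxy group on an aromatic carbon, para to a group of 8 heavy atoms, gives the first reading of any change at this position: in this assay it brings a number 30 percentage points lower from compound 2 to compound 4 (beyond the scatter). The position therefore takes a substituent with a stronger effect, not a weaker one. No measurement at hand bears on why this step occurs.

The compounds shown leave open whether an ethoxy group, a hydroxyl group or an amine at the same place would shift the number in the same direction. They also leave open how a methoxy group would act at another carbon of the ring.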